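This account rests on a few compounds, and the source may have more. Where it says the series, first, only, none or still open, it means among the compounds named here.

For the measured compounds named here, compound 1 `COc1cc(C)cc(-c2c(-c3ccnc(-c4ccc(N(C)C)cc4)c3)cnn2CC#N)c1` is one of two compounds measured in a functional assay on M14 cells (Homo sapiens) for cytotoxicity, read by sulforhodamine B assay, with a stated time of 48 h, tested at 0.01 uM (a lower number here means a stronger effect, a higher number a weaker effect of the compound at the concentration tested), and there compound 1 gives -19%, the lower of the two numbers. Going by the values given here, compound 2 `Cc1cc(O)cc(-c2nn(CC#N)cc2-c2ccnc(-c3ccc(N(C)C)cc3)c2)c1` gives 92% in this assay, far higher than compound 1 and beyond the usual scatter; these two differ in more than one place, so no single step joins them. Compound 3 `COc1cc(C)cc(-c2c(-c3ccnc(-c4ccc(C(C)=O)cc4)c3)cnn2CC#N)c1` has not yet been measured. It differs from compound 1 by acetyl in place of dimethylamino on an aromatic carbon. Among the compounds with values here, no measured pair shows this change, so the expected step of a number 44 percentage points higher from compound 1 to compound 3 (beyond the scatter) is a moderate rise. Compound 3 is therefore expected to give 25%, within -15% to 80%.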

Compound 3, a percentage reported as activity, at one concentration (the size of the read-out at that concentration, not a potency): 86%
Compound 3: middle estimate off by 61 percentage points, on the low side, and the stated range ends below it.
By their numbers in this assay, from the lowest: compound 1; then compounds 3 and 2 (each within the scatter of the next).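

In this assay, acetyl in place of dimethylamino on an aromatic carbon, para to a large group, gives a number 105 percentage points higher from compound 1 to compound 3 (beyond the scatter), so this position is highly sensitive to the change. The two groups have the same counts of heavy atoms and hydrogen-bond acceptors, so those counts alone do not set the read-out. No data shown here account for the step.

From the compounds shown here alone, it remains open whether a smaller amine such as methylamino, a morpholine ring or a carboxylic acid at this position would retain the effect of compound 1.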